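Oxazoline ethers: nitro for methyl on the aromatic ring

The compounds below may be only part of what the source reports. "The series", "measured", "known", "first", "only" and "open" are said of these compounds alone.

The series shares one core carrying an aryl ether. Going by the values given here, compound 1 `Cc1ccccc1OCC1=NCCO1` and compound 2 `Brc1ccc(OCC2=NCCO2)cc1` are the two measured members. In a toxicity assay on the whole organism with Rattus norvegicus as the target, at a dose of 100 mg/kg by the oral route (on this read-out lower numbers stand for a weaker effect and higher numbers for a stronger effect at the one dose given), compound 1 gives 10%, and in this assay compound 2 gives 5%; the two numbers lie within the scatter of each other, so no order between them can be read. Among the compounds with values here, compound 1 therefore stands together with compound 2 at the low end of the scale, with no measured step to lean on.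

Compound 3 `O=[N+]([O-])c1ccccc1OCC1=NCCO1` is not yet measured. It differs from compound 1 by nitro in place of methyl on an aromatic carbon. Nothing measured in the series tells how a nitro in place of methyl on an aromatic carbon acts here. With compound 1 giving 10% as the only anchor, the step from compound 1 to compound 3 in this assay is expected to be a number 2 percentage points higher from compound 1 to compound 3 (within the scatter), none beyond the scatter. Compound 3 is accordingly estimated to give 12% in this assay, in the range 0% to 35%.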

Compound 3, a percentage reported as activity, at one dose (the size of the read-out at that dose, not a potency): 20%
The estimate for compound 3 lay 8 percentage points below the measured number, within the range that was stated.
By their numbers in this assay, from the lowest: compounds 2, 1 and 3 (each within the scatter of the next, the first and the last beyond it).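

Going by these compounds alone, this is the first measured step: on an aromatic carbon of the six-membered ring, ortho to a group of 7 heavy atoms, nitro in place of methyl gives, in this assay, a number 10 percentage points higher from compound 1 to compound 3 (within the scatter). The position thus accepts a swap from 1 heavy atom to 3 heavy atoms, with 2 hydrogen-bond acceptors entering, and the read-out stays within the scatter of compound 1. Nothing measured on these compounds speaks to what lies behind the size of this step.

From the compounds shown here alone, whether an amine, a carboxylic acid or a longer chain on the same aromatic carbon would carry the number in this assay beyond the scatter stays open. Also open, going by these compounds, is whether nitro on another aromatic carbon would give a similar step: one step at one position sets no trend.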